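The source may hold more compounds than are shown below. What is called first, only, known or untested is meant among the compounds shown, and "the series" means these compounds.

Working notes on a series tested in an ADME assay (liver) for metabolic stability, with Liver microsome (Rattus norvegicus) as the target, using microsomes and NADPH, with a stated time of 30 min, tested at 1 uM; a higher number here means faster removal of the compound, a lower number slower removal. Compound 1 `Nc1ccc(S(=O)(=O)N2CCN(c3ncc(C(O)(C(F)(F)F)C(F)(F)F)cc3C#CC3CC3)CC2)cn1` gives 67 mL.min-1.g-1. Compound 2 `CC(C)n1cc(-c2cc(C(O)(C(F)(F)F)C(F)(F)F)cnc2N2CCN(S(=O)(=O)c3ccc(N)nc3)CC2)cn1` gives 198 mL.min-1.g-1, and compound 3 `NC(=O)c1cccc(-c2cc(C(O)(C(F)(F)F)C(F)(F)F)cnc2N2CCN(S(=O)(=O)c3ccc(N)nc3)CC2)c1` gives 63 mL.min-1.g-1. On these three numbers compound 1 stands second highest, nearest to compound 3 and furthest from compound 2: a 3.0-fold higher number from compound 1 to compound 2 (0.47 log units; beyond the scatter), whereas a 1.1-fold lower number from compound 1 to compound 3 (0.03 log units; within the scatter). Between the two aromatic replacements themselves, a 3.1-fold lower number from compound 2 to compound 3 (0.50 log units; beyond the scatter).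

Compound 4 `COc1cncc(-c2cc(C(O)(C(F)(F)F)C(F)(F)F)cnc2N2CCN(S(=O)(=O)c3ccc(N)nc3)CC2)c1` is the next member. Its difference from compound 1: 5-methoxypyridin-3-yl in place of 2-cyclopropylethynyl on an aromatic carbon. Within the data shown here, the steps that bear on it are the two in which the same 2-cyclopropylethynyl group of compound 1 was replaced by an aromatic group, giving compound 2 and compound 3. One of these moved beyond the scatter and the other stayed within it, so an aromatic group at this position can leave the number roughly unchanged or raise it modestly; nothing in the data points to a fall. Given a 3.0-fold higher number from compound 1 to compound 2 (0.47 log units; beyond the scatter) and a 1.1-fold lower number from compound 1 to compound 3 (0.03 log units; within the scatter), compound 4 is expected to move by a 1.6-fold higher number from compound 1 to compound 4 (0.22 log units; within the scatter), a rise smaller than that seen for compound 2 but beyond the scatter at its middle. Compound 4 is therefore estimated at 110 mL.min-1.g-1, with a range from 50 mL.min-1.g-1 to 250 mL.min-1.g-1 wide enough to cover both measured outcomes.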

Compound 4, intrinsic clearance in microsomes: 58 mL.min-1.g-1
For compound 4 the middle estimate is 1.9-fold (0.28 log units) above the measured one; measured number inside the range.
By their numbers in this assay, from the lowest: compounds 4, 3 and 1 (each within the scatter of the next); then compound 2.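

In this assay, the 5-methoxypyridin-3-yl group is a second aromatic replacement of 2-cyclopropylethynyl, after 3-carbamoylphenyl, that leaves the number within the scatter (a 1.2-fold lower number from compound 1 to compound 4 (0.06 log units; within the scatter)), and the two aromatic groups also stand level with each other (a 1.1-fold lower number from compound 3 to compound 4 (0.04 log units; within the scatter)). Among these compounds, this carbon, ortho to a large group, therefore accepts a larger group of 8 heavy atoms with 2 hydrogen-bond acceptors in place of one of 5 heavy atoms with none, without a change in clearance beyond the scatter, and the 1-isopropyl-1H-pyrazol-4-yl group of compound 2 now stands apart as the only group here with a clearly higher number (a 3.4-fold lower number from compound 2 to compound 4 (0.53 log units; beyond the scatter)). The high number thus goes with that one group and not with aromatic replacement as such, though no measurement at hand explains the difference.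

The compounds shown leave open whether the high number follows the isopropyl group or the pyrazole ring that carries it, which a 1-methyl-1H-pyrazol-4-yl group at the same carbon would separate. They also leave open whether the methoxy group matters to compound 4, as an unsubstituted pyridin-3-yl group would show.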